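This account rests on a few compounds, and the source may have more. Where it says the series, first, only, none or still open, it means among the compounds named here.

Compound 1 `CCCCCCCC/C=C\CCCCCCCCO[C@@]1(c2ccc(Cl)cc2)SC=C(C)n2c1noc2=O` and compound 2 `CCCCCCCC/C=C\CCCCCCCCO[C@@]1(c2ccc(Br)cc2)SC=C(C)n2c1noc2=O` share one core, while compound 3 `CC1=CSC(OCc2ccccc2)(c2ccc(Cl)cc2)c2noc(=O)n21` and compound 4 `CC1=CSC(OCc2ccccc2)(c2ccc(Br)cc2)c2noc(=O)n21` share another; the difference between the two cores is not broken down here. In a functional assay (Cavia porcellus) with Rattus norvegicus as the target (a higher number here means that more compound is needed for the effect, a lower number that less compound is needed), compound 1 gives 870 nM, and compound 2 gives 1260 nM. The change between them is bromo in place of chloro on an aromatic carbon, and a 1.4-fold higher number from compound 1 to compound 2 (0.16 log units; within the scatter). In this assay compound 3 gives 740 nM; its number lies within the scatter of both compound 1 and compound 2. Compound 4 carries the same change on the second core, (bromo in place of chloro on an aromatic carbon), at a place described in the same words. Because a 1.4-fold higher number from compound 1 to compound 2 (0.16 log units; within the scatter) stayed within the scatter, the step expected for compound 4 is a 1.4-fold higher number from compound 3 to compound 4 (0.13 log units; within the scatter). Compound 4 is therefore estimated to give 1000 nM, between 500 nM and 2000 nM.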

Compound 4, half-maximal effective concentration: 590 nM
Compound 4: middle estimate off by 1.7-fold (0.23 log units), on the high side; the range from low to high includes it.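

In this assay, replacing 4-chlorophenyl with 4-bromophenyl on the second core gives a 1.3-fold lower number from compound 3 to compound 4 (0.10 log units; within the scatter). Set beside the same change on the first core, this step does not differ from the earlier one: the same change on two cores in this assay, a 1.4-fold higher number (0.16 log units; within the scatter) from compound 1 to compound 2 and a 1.3-fold lower number (0.10 log units; within the scatter) from compound 3 to compound 4, 1.8-fold (0.26 log units) apart, within the scatter of two such steps. The change therefore leaves the number within the scatter on both cores, but since neither step stands clear of that scatter, the pair cannot show whether a real effect of the change would carry from one core to the other, and the opposite directions of the two steps carry no weight.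

As far as these compounds go, what a fluoro, a methyl or a methoxy group would do at the same place stays open. So does whether the change would behave alike on a third core.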